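Chloro to fluoro swap on the pendant phenyl ring

The source may hold more compounds than are shown below. What is called first, only, known or untested is meant among the compounds shown, and "the series" means these compounds.

Measured so far:
- compound 2 `O=C(Nn1c(-c2cccc([N+](=O)[O-])c2)nc2c(-c3ccc(Cl)cc3)n[nH]c2c1=O)c1ccccc1`: 88.6%
- compound 1 `O=C(Nn1c(-c2cccc([N+](=O)[O-])c2)nc2c(-c3cccc(Cl)c3)n[nH]c2c1=O)c1ccccc1`: "not determined" (no result reported)

Among the compounds with values here, in a functional assay on A549 cells (Homo sapiens) for cytotoxicity, read by sulforhodamine B assay, with a stated time of 2 days, tested at 100 uM (a higher number here means more inhibition at the concentration tested (going by the name of the read-out), a lower number less inhibition), compound 2 gives 88.6%, the only number so far; in this assay compound 1 gives "not determined" (no result reported), so compound 2 cannot be placed against anything. Compound 3 `O=C(Nn1c(-c2cccc([N+](=O)[O-])c2)nc2c(-c3ccc(F)cc3)n[nH]c2c1=O)c1ccccc1` is the next entry. Its change from compound 2 is fluoro in place of chloro on an aromatic carbon. Within the data shown here, with no measured step between compounds, the size of the step is open; a small drop is expected, within or just beyond the scatter. For compound 3 a value of 80% is estimated, in the range 60% to 95%, a change of a number 8.6 percentage points lower from compound 2 to compound 3 (within the scatter).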

Compound 3, a percentage reported as inhibition, at one concentration (the size of the read-out at that concentration, not a potency): 80.7%
For compound 3 the middle estimate is 0.7 percentage points below the measured one; the range from low to high includes it.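

In this assay, within the data shown here, the change from 4-chlorophenyl to 4-fluorophenyl gives the first readable step at this place, a number 7.9 percentage points lower from compound 2 to compound 3 (within the scatter), so on this aromatic carbon, para to a large group, the two halogens cannot be told apart. This rests on a single pair at one concentration and is no comparison of potency. No measurement on hand explains the step.

The placement of chloro in compound 1 cannot be assessed, as compound 1 gives "not determined" (no result reported). On these data alone, whether an amine or a carboxylic acid at this place would keep the inhibition stays open.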